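A few compounds are considered here, and "the series" means these few. Any claim that something is new, unique, unknown or untested is made for them only; others in the source may bear on it.

Measured in a physicochemical assay for solubility, in phosphate buffer, at pH 6.5; on this read-out lower numbers stand for lower solubility and higher numbers for higher solubility:
- Compound 1 `COC(=O)C1(c2ccc(NC(=O)Nc3cccnc3Oc3ccccc3C(C)(C)C)cc2)CC1`: 1 ug/mL
- Compound 2 `CC(C)(C)c1ccccc1Oc1ncccc1NC(=O)Nc1ccc(-c2ccccc2CO)cc1F`: 2 ug/mL
- Compound 3 `CC(C)(C)c1ccccc1Oc1ncccc1NC(=O)Nc1ccc(N2CCCCC2)cc1`: 9 ug/mL

Compound 2, at 2 ug/mL, cannot be told apart from compound 1, at 1 ug/mL, since the two lie within the scatter of each other. Both sit clearly under compound 3, at 9 ug/mL.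

The next compound to be read is compound 4 `CN(C)Cc1cccc(-c2ccc(NC(=O)Nc3cccnc3Oc3ccccc3C(C)(C)C)c(F)c2)c1`. It differs from compound 2 as follows: 3-((dimethylamino)methyl)phenyl in place of 2-(hydroxymethyl)phenyl on an aromatic carbon. In words, 3-((dimethylamino)methyl)phenyl stands in place of 2-(hydroxymethyl)phenyl on an aromatic carbon, meta to a fluoro group and para to a large group.

Among the measured compounds shown here, no measured step makes this exact exchange. The only one available is a 9.0-fold higher number from compound 1 to compound 3 (0.95 log units; beyond the scatter), a modest step beyond the scatter, with piperidin-1-yl in place of 1-(methoxycarbonyl)cyclopropyl. Its bearing is indirect: the entering group there and the one here both hold nitrogen, and neither leaving group does. On that thin basis, a step of similar size and the same direction is expected in this assay, with wide uncertainty.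

The expected change is a 4.0-fold higher number from compound 2 to compound 4 (0.60 log units; beyond the scatter), an estimated modest rise.

For compound 4 the estimated value is 8 ug/mL, with an expected range from 2 ug/mL to 40 ug/mL.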

Compound 4, solubility: 17 ug/mL
Compound 4: the middle estimate sits 2.1-fold (0.33 log units) below what was measured; measured number inside the range.
By their numbers in this assay, from the lowest: compounds 1 and 2 (each within the scatter of the next); then compounds 3 and 4 (each within the scatter of the next).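

At this position, on an aromatic carbon meta to a fluoro group and para to a large group, the read-out of this assay moves with the aryl group carried, even though a six-membered aromatic ring of carbon only both leaves and enters: 3-((dimethylamino)methyl)phenyl in place of 2-(hydroxymethyl)phenyl gives an 8.5-fold higher number from compound 2 to compound 4 (0.93 log units; beyond the scatter). Alongside a 9.0-fold higher number from compound 1 to compound 3 (0.95 log units; beyond the scatter), this makes two steps in which a group holding nitrogen replaces one without it and the number goes up beyond the scatter, and none of the four compounds goes against that, though the entering groups differ, one being piperidin-1-yl and the other an aryl group. Nothing measured here accounts for the higher number in either step.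

The step changes several things at once: the hydroxymethyl group gives way to a (dimethylamino)methyl group, its place on the phenyl ring shifts, and the group grows from 8 to 10 heavy atoms, so the compounds shown do not separate these changes. From the compounds shown here alone, a 3-(hydroxymethyl)phenyl or a 2-((dimethylamino)methyl)phenyl group would bear on that, and whether a carboxylic acid on the phenyl ring would move the number in the same direction also remains open.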